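The source may report more compounds than this note shows. Statements on the series, on what has been measured and on what is new or still open speak of the compounds shown alone.

In a functional assay on HeLa cells (Homo sapiens) for inhibition, read by MTT assay, with a stated time of 4 days (a higher number here means a weaker inhibitor, a lower number a stronger inhibitor), compound 2 `COc1cc(NC(C)CCCNC(=O)NNC(=O)Nc2ccc(Cl)c(C(F)(F)F)c2)c2ncccc2c1` gives 17000 nM. Compound 3 `COc1cc(NC(C)CCCNC(=O)NNC(=O)NCCO)c2ncccc2c1` gives 196000 nM, the higher of the two actual numbers, a gap seen in a 12-fold higher number from compound 2 to compound 3 (1.06 log units; beyond the scatter). Compound 1 `COc1cc(NC(C)CCCNC(=O)NNC(=O)NCCCCCO)c2ncccc2c1` is reported only as a limit, >= 250000 nM. The change to compound 4 `COc1cc(NC(C)CCCNC(=O)NNC(=O)N(CCO)CCO)c2ncccc2c1` is 2-hydroxyethyl in place of hydrogen on an amide-type nitrogen. The large steps of an at least 14-fold lower number from compound 1 to compound 2 (1.16 log units; beyond the scatter) and a 12-fold higher number from compound 2 to compound 3 (1.06 log units; beyond the scatter) both involve the 4-chloro-3-(trifluoromethyl)phenyl group, which plays no part here. The closer guide is an at least 1.2-fold lower number from compound 1 to compound 3 (0.10 log units; that floor lies within the scatter), which links two hydroxy-bearing compounds and stays within the scatter. The expected step is therefore small, a 1.0-fold higher number from compound 3 to compound 4 (0.01 log units; within the scatter), with none expected beyond the scatter. Compound 4 is estimated at 200000 nM, with an expected range of 110000 nM to 350000 nM.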

Compound 4, half-maximal inhibitory concentration: > 250000 nM
Compound 4: a limit, no number; the forecaster's own chance of this, stated with the estimate: 35%; at least 1.2-fold (0.09 log units) between middle value and limit.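

In this assay compound 4 is reported only as a limit: the limit of > 250000 nM in this assay, at which 1 of the 4 values shown sits. Placing 2-hydroxyethyl in place of hydrogen on this amide-type nitrogen gives an at least 1.2-fold higher number from compound 3 to compound 4 (0.10 log units; that floor lies within the scatter), so no gain in strength appears, but the true size of the change stays unknown. Swapping the (4-chloro-3-(trifluoromethyl)phenyl)amino group for bis(2-hydroxyethyl)amino gives an at least 14-fold higher number from compound 2 to compound 4 (1.16 log units; beyond the scatter), a large loss. The step between compound 1 and compound 4 cannot be read, since both are limits. On these data alone, whether an amine or a carboxylic acid at the end of this chain would give a measurable number remains open.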